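A few compounds are considered here, and "the series" means these few. Any claim that something is new, unique, unknown or untested is made for them only; others in the source may bear on it.

Of the compounds shown here, two built on one shared core have been tested in an ADME assay on HCT-116 cells (Homo sapiens) for cytotoxicity, read by CellTiter-Glo, with a stated time of 72 h; on this read-out lower numbers stand for stronger inhibition and higher numbers for weaker inhibition. Compound 1 `Cc1cc(Cl)cc(Cl)c1S(=O)(=O)N1CCC(N2CCC(C)CC2)CC1` reaches only a limit of the assay, > 5000 nM. Compound 2 `Cc1noc(C)c1S(=O)(=O)N1CCC(N2CCC(C)CC2)CC1` likewise reaches only a limit of the assay, > 10000 nM. Compound 2 therefore stands at the limit of > 10000 nM in this assay, at which 1 of the 2 values shown sits. Compound 1 stands at the limit of > 5000 nM in this assay, at which 1 of the 2 values shown sits. For the measured compounds named here, neither result is a number, so no measured step between them can be counted, and nothing so far shows where a change on the sulfonyl sulfur leads.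

Compound 3 `CC1CCN(C2CCN(S(=O)(=O)c3nccn3C)CC2)CC1` has not yet been measured. It differs from compound 2 in one place: 1-methyl-1H-imidazol-2-yl in place of 3,5-dimethyl-1,2-oxazol-4-yl on a sulfonyl sulfur. Going by the values given here, with no measured step available, the expectation rests on the two limits alone. The expected step, a step that the limit leaves unreadable from compound 2 to compound 3, is small and within the usual scatter. Compound 3 is expected to give about 20000 nM, with a range from 5000 nM to 80000 nM.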

Compound 3, half-maximal inhibitory concentration: > 10000 nM
Compound 3: a limit, no number (the forecaster's own chance of this, stated with the estimate: 85%); the middle value does not contradict the limit.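

In this assay, for the compounds shown here, compound 2 and compound 3 each give only a limit and not a number, so no step between them can be read. The compounds shown leave open whether any group on the sulfonyl sulfur would give a number rather than a limit.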